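The compounds below may be only part of what the source reports. "The series", "measured", "known", "first", "only" and "open" are said of these compounds alone.

Measured so far, in a functional assay on MCF7 cells (Homo sapiens) for inhibition, with a stated time of 96 h; a higher number here means a weaker inhibitor, a lower number a stronger inhibitor:
compound 1 `COc1cc(C(=O)c2cn(-c3cccc(C)c3)cc2-c2ccco2)cc(OC)c1OC` gives 23 nM
compound 2 `COc1cc(C(=O)c2cn(-c3cccc(C)c3)cc2-c2ccoc2)cc(OC)c1OC` gives 21 nM
compound 3 `COc1cc(C(=O)c2cn(-c3ccc(F)cc3)cc2-c2ccco2)cc(OC)c1OC` gives 17 nM

The three values lie within the scatter of one another, so no ordering among them is claimed. Compound 4 `COc1cc(C(=O)c2cn(-c3ccc(F)cc3)cc2-c2ccoc2)cc(OC)c1OC` is not yet measured in this assay. It is reached from compound 3 by the change (furan-3-yl in place of furan-2-yl on an aromatic carbon). The same change has already been made once among the measured compounds, as furan-3-yl in place of furan-2-yl on an aromatic carbon, and there it produced a 1.1-fold lower number from compound 1 to compound 2 (0.04 log units; within the scatter). The two cores differ by 4-fluorophenyl in place of 3-methylphenyl on an aromatic nitrogen, so the place of the change is not identical word for word: in the earlier pair it lies two ring bonds from the ring atom that bears a 3-methylphenyl group, in the new pair two ring bonds from the ring atom that bears a 4-fluorophenyl group. It is the same kind of change, not the same change. Going by the values given here, the single precedent, a 1.1-fold lower number from compound 1 to compound 2 (0.04 log units; within the scatter), lay within the scatter. On that basis the step is expected to be a 1.1-fold lower number from compound 3 to compound 4 (0.03 log units; within the scatter), of like size. Compound 4 is accordingly estimated at 16 nM, with a range of about 8 nM to 32 nM.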

Compound 4, half-maximal inhibitory concentration: 15 nM
The estimate for compound 4 lay 1.1-fold (0.03 log units) above the measured number; the measured number falls inside the stated range.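

In this assay the change to furan-3-yl from furan-2-yl gives a 1.1-fold lower number from compound 3 to compound 4 (0.05 log units; within the scatter) on the 4-fluorophenyl core, and this agrees with the same change on the 3-methylphenyl core:
the same change on two cores in this assay, a 1.1-fold lower number (0.04 log units; within the scatter) from compound 1 to compound 2 and a 1.1-fold lower number (0.05 log units; within the scatter) from compound 3 to compound 4, 1.0-fold (0.01 log units) apart, within the scatter of two such steps
The change to 4-fluorophenyl from 3-methylphenyl gives a 1.4-fold lower number from compound 2 to compound 4 (0.15 log units; within the scatter) on the furan-3-yl core, and it likewise agrees with its earlier counterpart on the furan-2-yl core: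
the same change on two cores in this assay, a 1.4-fold lower number (0.13 log units; within the scatter) from compound 1 to compound 3 and a 1.4-fold lower number (0.15 log units; within the scatter) from compound 2 to compound 4, 1.0-fold (0.01 log units) apart, within the scatter of two such steps
Going by these compounds alone, both changes therefore carry from one core to the other without a step beyond the scatter, but since no step is resolved from the scatter, this shows neither an effect of either change nor any ranking of the four compounds, and it says nothing about cores other than these.

Still open, on these data alone, is whether a carboxylic acid or a dimethylamino group in place of the furan ring would give a step beyond the scatter. The same question stands for a longer alkyl chain in place of the aromatic group on the ring nitrogen.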